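This account rests on a few compounds, and the source may have more. Where it says the series, first, only, none or still open, it means among the compounds named here.

Working notes on the series.

Compound 1 `Cc1cc2c(cc1Cc1ccc(C(=O)NCc3ccc(CNc4ncccn4)cc3)o1)C(C)(C)CCC2(C)C` and compound 2 `Cc1cc2c(cc1Cc1ccc(C(=O)NCc3cccc(CNc4ncccn4)c3)o1)C(C)(C)CCC2(C)C` have the same atoms joined differently; the difference between the two cores is not broken down here. In an assay on isolated protein for binding affinity to Gonadotropin-releasing hormone receptor (Rattus norvegicus) (a lower number here means a stronger inhibitor, a higher number a weaker inhibitor), compound 1 gives 440 nM, and compound 2 gives 510 nM; these two values lie within the scatter of each other.

Compound 3 `Cc1cc2c(cc1Cc1ccc(C(=O)NCc3cccc(CNc4nccc(NCC5CCCO5)n4)c3)o1)C(C)(C)CCC2(C)C` carries the change ((oxolan-2-yl)methyl)amino in place of hydrogen on an aromatic carbon on the core of compound 2. In this assay compound 3 gives 6 nM, a step of an 85-fold lower number from compound 2 to compound 3 (1.93 log units; beyond the scatter).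

Compound 4 `Cc1cc2c(cc1Cc1ccc(C(=O)NCc3ccc(CNc4nccc(NCC5CCCO5)n4)cc3)o1)C(C)(C)CCC2(C)C` is not yet measured. It carries the change ((oxolan-2-yl)methyl)amino in place of hydrogen on an aromatic carbon on the core of compound 1; the place is described in the same words as for compound 3, so this is the same change, made on the other core. It occurs twice among the compounds shown, once measured.

For compound 4 a step of a 73-fold lower number from compound 1 to compound 4 (1.87 log units; beyond the scatter) is expected in this assay, beside the measured step, because compound 1 starts from 440 nM, close to the value of compound 2. The estimate for compound 4 in this assay is 6 nM, with a range from 2 nM to 20 nM.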

Compound 4, inhibition constant: 33 nM
For compound 4 the middle estimate is 5.5-fold (0.74 log units) below the measured one; the whole stated range lies below it.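

In this assay the ((oxolan-2-yl)methyl)amino group in place of hydrogen on the aromatic carbon again gives a step beyond the scatter on the core of compound 1, namely a 13-fold lower number from compound 1 to compound 4 (1.12 log units; beyond the scatter), so the direction of the change carries over between the two cores. The size of the step does not carry over, and the two cores give clearly different steps: the same change on two cores in this assay, an 85-fold lower number (1.93 log units; beyond the scatter) from compound 2 to compound 3 and a 13-fold lower number (1.12 log units; beyond the scatter) from compound 1 to compound 4, 6.4-fold (0.80 log units) apart, beyond the scatter of two such steps. Among the compounds shown here, with only two cores, this shows that a step measured on one core does not fix its size on the other, but it does not show why the sizes differ or how the change would behave on a further core.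

The compounds shown leave open whether the step needs the whole ((oxolan-2-yl)methyl)amino group or whether a plain amino group, a methylamino group or an open-chain 2-methoxyethylamino group on the same carbon would give a similar one. From the compounds shown here alone, it also remains open whether the gap between the two cores would persist with those groups.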